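Cyanomethyl to ethyl on the aromatic nitrogen

This account rests on a few compounds, and the source may have more. Where it says the series, first, only, none or still open, it means among the compounds named here.

In a functional assay on HepG2 cells (Homo sapiens) for cytotoxicity, read by sulforhodamine B assay, with a stated time of 48 h (on this read-out lower numbers stand for stronger inhibition and higher numbers for weaker inhibition), compound 1 (`N#Cc1c(-c2ccc(Cl)cc2)cc(-c2ccc(Cl)cc2)n([C@@H]2O[C@H](CO)[C@@H](O)[C@H]2O)c1=O`) gives 6.9 ug/mL and compound 2 (`N#Cc1c(-c2ccc(Cl)cc2)cc(-c2ccc(Cl)cc2)n(CC2CO2)c1=O`) gives 6.2 ug/mL on the shared core. Compound 3 (`N#CCn1c(-c2ccc(Cl)cc2)cc(-c2ccc(Cl)cc2)c(C#N)c1=O`) is recorded as "not active" (no number reported) in this assay and carries no single number, so no step size can be computed from it.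

Compound 4 (`CCn1c(-c2ccc(Cl)cc2)cc(-c2ccc(Cl)cc2)c(C#N)c1=O`) alters one group of compound 3: methyl in place of cyano on a saturated chain carbon bound to an aromatic nitrogen (methyl in place of cyano on a saturated chain carbon bound to an aromatic nitrogen, which also reads as cyanomethyl to ethyl).

The measured step of a 1.1-fold lower number from compound 1 to compound 2 (0.05 log units; within the scatter) is the only one that bears on this, and it too changes the substituent on an aromatic nitrogen. Against it stands compound 3, whose cyanomethyl group goes with "not active" (no number reported) in this assay on the same core, so a change at that nitrogen does not always leave the result in place. The size of the step from compound 3 cannot be stated. The expected direction is toward a measurable number, near or somewhat higher than those of the two measured compounds, with a real chance of no number at all. For compound 4 an expected value of 10 ug/mL is estimated, within a range of 4 ug/mL to 40 ug/mL if a number is reported.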

Compound 4, half-maximal inhibitory concentration: 22.3 ug/mL
For compound 4 the middle estimate is 2.2-fold (0.35 log units) below the measured one, and the stated range covers the measured number.
By their numbers in this assay, from the lowest: compounds 2 and 1 (each within the scatter of the next); then compound 4.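

In this assay, ethyl in place of 3,4-dihydroxy-5-(hydroxymethyl)oxolan-2-yl on an aromatic nitrogen gives a 3.2-fold higher number from compound 1 to compound 4 (0.51 log units; beyond the scatter), and methyl in place of oxiran-2-yl on a saturated chain carbon bound to an aromatic nitrogen gives a 3.6-fold higher number from compound 2 to compound 4 (0.56 log units; beyond the scatter), so this position now shows measured changes beyond the scatter, which the earlier step of a 1.1-fold lower number from compound 1 to compound 2 (0.05 log units; within the scatter) did not. Cyanomethyl to ethyl also replaces the "not active" entry of compound 3 with a number for compound 4, which shows that this change can separate a compound with no reported number from one with a number, although steps from compound 3 cannot be read and their size stays unknown. Nothing given here accounts for these differences at the nitrogen.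

The compounds shown leave open how a longer chain such as propyl or butyl would read at this nitrogen, and how an ethyl chain ending in an amine or a carboxylic acid would read there. They also leave open whether a nitrile at the end of a longer chain would go with "not active", as cyanomethyl does in compound 3.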